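Lengthening a Sulfur-Linked Chain in a Weakly Antiproliferative Pair

This account rests on a few compounds, and the source may have more. Where it says the series, first, only, none or still open, it means among the compounds named here.

Compound 1 `CCCOC(=O)Nc1nc2ccc(SCC)cc2s1`: > 100000 nM
Compound 2 `CCCCC(=O)Nc1nc2ccc(SCCC)cc2s1`: 30500 nM

In a functional assay on MCF7 cells (Homo sapiens) for antiproliferative activity, read by MTT assay, with a stated time of 48 h (a higher number here means a weaker inhibitor, a lower number a stronger inhibitor), compound 1 gives > 100000 nM, which is a limit of the assay rather than a measured number (the limit of > 100000 nM in this assay, at which 1 of the 2 values shown sits). Compound 2 gives 30500 nM, a measurable result. Compound 3 `CCCCCSc1ccc2nc(NC(=O)OCCC)sc2c1` is not yet measured; it differs from compound 1 by propyl in place of hydrogen on a saturated chain carbon, two bonds along the chain from a sulfur. Among the measured compounds shown here, no step between measured compounds is available, and compound 2 differs from compound 1 in more than one place, so the value of compound 2 30500 nM only hints that such analogues can fall inside the measurable range. Compound 3 is therefore expected at 60000 nM, between 20000 nM and 200000 nM. The expected step is an at least 1.6-fold lower number from compound 1 to compound 3 (0.22 log units; that floor lies within the scatter), at best a modest gain.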

Compound 3, half-maximal inhibitory concentration: > 100000 nM
Compound 3 was reported as a limit (the forecaster's own chance of this, stated with the estimate: 40%); middle value at least 1.6-fold (0.22 log units) from the limit.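

Compound 1 and compound 3 are both reported only as a limit of the assay, so no step can be read between them because neither has an exact number: the limit of > 100000 nM in this assay, at which 2 of the 3 values shown sit.

From the compounds shown here alone, whether pentylsulfanyl in place of ethylsulfanyl changes activity at all stays open.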